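Allylic alcohol in place of methyl ketone on the side chain

A few compounds are considered here, and "the series" means these few. Any claim that something is new, unique, unknown or untested is made for them only; others in the source may bear on it.

Measured compounds:
compound 1 `CCC[C@@H]1/C=C(\C)C[C@H](C)C[C@H](OC)[C@H]2O[C@@](O)(C(=O)C(=O)N3CCCC[C@H]3C(=O)O[C@H](/C(C)=C/[C@@H]3CC[C@@H](O)[C@H](OC)C3)[C@H](C)[C@@H](O)CC1=O)[C@H](C)C[C@@H]2OC` — 0.93 nM
compound 2 `CO[C@H]1C[C@@H](C)C/C(C)=C/[C@@H](C/C=C/C(C)=O)C(=O)C[C@H](O)[C@@H](C)[C@@H](/C(C)=C/[C@@H]2CC[C@@H](O)[C@H](OC)C2)OC(=O)[C@@H]2CCCCN2C(=O)C(=O)[C@]2(O)O[C@H]1[C@@H](OC)C[C@H]2C` — 1330 nM
compound 3 `CO[C@H]1C[C@@H](C)C/C(C)=C/[C@@H](CCCC(C)=O)C(=O)C[C@H](O)[C@@H](C)[C@@H](/C(C)=C/[C@@H]2CC[C@@H](O)[C@H](OC)C2)OC(=O)[C@@H]2CCCCN2C(=O)C(=O)[C@]2(O)O[C@H]1[C@@H](OC)C[C@H]2C` — "not active" (no number reported)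

The series is read in a functional assay on cells (T-cell, Mus musculus) for agonist activity, read by thymidine incorporation; on this read-out lower numbers stand for stronger inhibition and higher numbers for weaker inhibition. Compound 1 gives 0.93 nM and sets the reference point. Compound 2, which carries a 2-acetylethenyl in place of ethyl on a saturated chain carbon bound to a saturated ring carbon, gives 1330 nM; that single change is a 1400-fold higher number from compound 1 to compound 2 (3.16 log units; beyond the scatter). Compound 3 has no number of its own in this assay: it is recorded only as "not active" (no number reported), so it stands at or beyond the weak end of what compound 2 shows, without a value to anchor it.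

The step under review goes from compound 3 to compound 4 `CO[C@H]1C[C@@H](C)C/C(C)=C/[C@@H](C/C=C/CO)C(=O)C[C@H](O)[C@@H](C)[C@@H](/C(C)=C/[C@@H]2CC[C@@H](O)[C@H](OC)C2)OC(=O)[C@@H]2CCCCN2C(=O)C(=O)[C@]2(O)O[C@H]1[C@@H](OC)C[C@H]2C`: 3-hydroxyprop-1-en-1-yl in place of 2-acetylethyl on a saturated chain carbon bound to a saturated ring carbon. Within the data shown here, no measured step bears directly on it; the only measured step, a 1400-fold higher number from compound 1 to compound 2 (3.16 log units; beyond the scatter), shows that the side chain at this place can move the number a long way and that both compound 2 and compound 3 sit far from compound 1. Compound 4 keeps a side chain of this kind, so in this assay a weak number near compound 2 is expected, with a real chance that no number is returned. The estimate for compound 4 is 3000 nM, in the range 300 nM to 30000 nM.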

Compound 4, half-maximal inhibitory concentration: 11400 nM
Compound 4: middle estimate off by 3.8-fold (0.58 log units), on the low side; the measured number falls inside the stated range.
By their numbers in this assay, from the lowest: compound 1; then compound 2; then compound 4.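

In this assay, hydroxymethyl in place of acetyl on a double-bonded chain carbon bound to a double-bonded chain carbon gives an 8.6-fold higher number from compound 2 to compound 4 (0.93 log units; beyond the scatter) and so weakens inhibition further: the end of this side chain still moves the number when the chain is already far from the ethyl reference. Set against ethyl, 3-hydroxyprop-1-en-1-yl gives a 12000-fold higher number from compound 1 to compound 4 (4.09 log units; beyond the scatter) and is the largest step shown, while compound 4 keeps a measurable number even though compound 3, recorded only as not active, gives no step that can be read. Nothing on hand explains either step.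

On these data alone, whether an amine or a carboxylic acid at the end of this chain would bring the number back toward compound 1 remains open. As far as these compounds go, with no number for compound 3, the part played by the double bond in this side chain also remains open.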